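The compounds below may be only part of what the source reports. "The series", "measured", "known", "first", "only" and "open" are said of these compounds alone.

Compounds with numbers in hand:
Compound 1 `O=C(O)CCC(=O)N(C1CC1)[C@H]1c2ccccc2N(C(=O)c2cccc(F)c2)[C@H]2CC[C@H]21`: 16 uL/min
Compound 2 `O=C(O)COC(=O)N(C1CC1)[C@H]1c2ccccc2N(C(=O)c2ccc(OC(F)(F)F)cc2)[C@H]2CC[C@H]21`: 18 uL/min
Compound 3 `O=C(O)CCC(=O)N(C1CC1)[C@H]1c2ccccc2N(C(=O)c2ccc(F)cc2)[C@H]2CC[C@H]21`: 14 uL/min

In an ADME assay on cells (Hepatocyte, Rattus norvegicus) for metabolic stability (on this read-out lower numbers stand for slow clearance and higher numbers for fast clearance), compound 3 gives 14 uL/min, a number that lies within the scatter of the values of compound 1 and compound 2. For the measured compounds named here, the only step measured in one place, a 1.1-fold lower number from compound 1 to compound 3 (0.06 log units; within the scatter), concerns a different change and stays within the scatter. Compound 4 `O=C(O)CCC(=O)N(C1CC1)[C@H]1c2ccccc2N(C(=O)c2ccc(OC(F)(F)F)cc2)[C@H]2CC[C@H]21` arises from compound 3 by trifluoromethoxy in place of fluoro on an aromatic carbon. Going by the values given here, no measured step covers this change; compound 2 carries the trifluoromethoxy group but on another chain, and its value and that of compound 3 sit within the scatter of each other. Compound 4 is therefore expected to show a 1.2-fold higher number from compound 3 to compound 4 (0.08 log units; within the scatter), nothing beyond the scatter, and its estimated value is 17 uL/min with a range from 9 uL/min to 32 uL/min.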

Compound 4, intrinsic clearance in a liver preparation (reported as CLH), per the amount of preparation that the assay uses: 13 uL/min
Beside the measured number, compound 4's estimate is 1.3-fold (0.12 log units) above it; measured number inside the range.
By their numbers in this assay, from the lowest: compounds 4, 3, 1 and 2 (each within the scatter of the next).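

Trifluoromethoxy in place of fluoro on this aromatic carbon, para to a large group, gives in this assay a 1.1-fold lower number from compound 3 to compound 4 (0.03 log units; within the scatter) and so stays within the scatter. With the aromatic group now held constant, 2-carboxyethyl in place of carboxymethoxy can be read directly and gives a 1.4-fold lower number from compound 2 to compound 4 (0.14 log units; within the scatter) within the scatter, while 4-(trifluoromethoxy)phenyl in place of 3-fluorophenyl gives a 1.2-fold lower number from compound 1 to compound 4 (0.09 log units; within the scatter) also within the scatter. No measurement here accounts for these results. On these data alone, whether an amine on this aromatic carbon, or a longer chain in place of 2-carboxyethyl, would move the number beyond the scatter remains open.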